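This account rests on a few compounds, and the source may have more. Where it says the series, first, only, none or still open, it means among the compounds named here.

Compound 2, `Cc1cccc(C)c1NC(=O)CN1CCC(c2cccc[n+]2[O-])CC1`, gives 68% in a functional assay on HEK293 cells for agonist activity at D(4) dopamine receptor (Homo sapiens), read by FLIPR; on this read-out lower numbers stand for smaller maximal responses and higher numbers for larger maximal responses. Within the data shown here, on the two numbers known, compound 2 stands highest; compound 1, `CSc1cccc(NC(=O)CN2CCC(c3cccc[n+]3[O-])CC2)c1`, gives 56% in this assay, and the one step so far, a number 12 percentage points higher from compound 1 to compound 2 (beyond the scatter), is the only guide to what changes on this amide-type nitrogen can do. Compound 3, `O=C(CN1CCC(c2cccc[n+]2[O-])CC1)Nc1cccc(Cl)c1Cl`, has not been measured. It differs from compound 2 in one place: 2,3-dichlorophenyl in place of 2,6-dimethylphenyl on an amide-type nitrogen. The step from compound 1 to compound 2 bears on this, since it exchanged an aryl group on the same amide-type nitrogen and gave a modest rise; a second exchange at that place could plausibly move the number by a similar modest amount in either direction, so no large step is expected. Compound 3 is estimated at 58%, within 40% to 76%, which means an expected step of a number 10 percentage points lower from compound 2 to compound 3 (within the scatter).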

Compound 3, largest response reached (reported as efficacy), in percent of the reference or control that the assay uses: 66%
For compound 3 the middle estimate is 8 percentage points below the measured one; the range from low to high includes it.
By their numbers in this assay, from the lowest: compounds 1, 3 and 2 (each within the scatter of the next, the first and the last beyond it).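

In this assay, moving to 2,3-dichlorophenyl on the amide-type nitrogen gives a number 2 percentage points lower from compound 2 to compound 3 (within the scatter) and so shows that a chlorine-bearing aryl group and a methyl-bearing one are not told apart at this place. Compared with 3-(methylsulfanyl)phenyl, the same group gives a number 10 percentage points higher from compound 1 to compound 3 (within the scatter) and compound 3 therefore cannot be separated from either of the others, even though a number 12 percentage points higher from compound 1 to compound 2 (beyond the scatter) remains the one step that clears the scatter. Nothing available accounts for these numbers.

On these data alone, all three compounds carry a substituted phenyl group at this place, so it stays open how an unsubstituted phenyl, a pyridine ring or a benzyl group would read. Also open, as far as these compounds go, is what an amine or a carboxylic acid on the aryl ring would do.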